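Cyclohexyl in place of trifluoromethylbenzyl on the shared core

The source may hold more compounds than are shown below. What is called first, only, known or untested is meant among the compounds shown, and "the series" means these compounds.

Three compounds sharing one core have been run in an ADME assay on HepG2 cells (Homo sapiens) for cytotoxicity, read by luminescence, CellTiter-Glo and ATP content, with a stated time of 72 h; on this read-out higher numbers stand for an effect only at larger amounts of compound and lower numbers for an effect already at smaller amounts. Compound 1 `CCC(CC)c1ccc2c(NCCCNCc3cccc(OC)c3O)ccnc2c1` gives 410 nM, compound 2 `COc1cccc(CNCCCNc2ccnc3cc(Oc4ccc(C(C)(C)C)cc4)ccc23)c1O` gives 1500 nM, and compound 3 `COc1cccc(CNCCCNc2ccnc3cc(Cc4cccc(C(F)(F)F)c4)ccc23)c1O` gives 1720 nM. Compound 3 therefore stands with the highest number of the three, though its gap to compound 2 is within the scatter, while its gap to compound 1 is beyond it. The measured steps show a 3.7-fold higher number from compound 1 to compound 2 (0.56 log units; beyond the scatter), a 4.2-fold higher number from compound 1 to compound 3 (0.62 log units; beyond the scatter) and a 1.1-fold higher number from compound 2 to compound 3 (0.06 log units; within the scatter).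

Compound 4 `COc1cccc(CNCCCNc2ccnc3cc(C4CCCCC4)ccc23)c1O` differs from compound 3 in one place: cyclohexyl in place of 3-(trifluoromethyl)benzyl on an aromatic carbon. Among the measured compounds shown here, no measured step involves a cyclohexyl group, so the nearest guidance comes from compound 1, whose pentan-3-yl, like cyclohexyl, carries no aromatic ring and gave the low number 410 nM. Both steps away from compound 1 toward aromatic-bearing groups raised the number by a modest amount. Compound 4 is therefore expected to fall between compound 1 and compound 3, estimated at 700 nM in this assay, in a range from 300 nM to 1700 nM. This estimate means a step of a 2.5-fold lower number from compound 3 to compound 4 (0.39 log units; beyond the scatter).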

Compound 4, half-maximal effective concentration: 1080 nM
Estimate against measurement, compound 4: 1.5-fold (0.19 log units) below; low and high end bracket the measured number.
By their numbers in this assay, from the lowest: compound 1; then compounds 4, 2 and 3 (each within the scatter of the next).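

In this assay, cyclohexyl does not separate from the two larger groups that carry an aromatic ring: the step of a 1.6-fold lower number from compound 3 to compound 4 (0.20 log units; within the scatter) and the step of a 1.4-fold lower number from compound 2 to compound 4 (0.14 log units; within the scatter) both lie within the scatter. The step of a 2.6-fold higher number from compound 1 to compound 4 (0.42 log units; beyond the scatter) lies beyond it, so a non-aromatic ring on this aromatic carbon reads with 3-(trifluoromethyl)benzyl and 4-(tert-butyl)phenoxy, and among these four groups only pentan-3-yl stands apart. No measured evidence explains this result.

The compounds shown leave open whether the separation of compound 1 follows from having an open-chain group rather than a ring at this place. A straight hexyl chain, a cyclopentyl ring or a piperidine ring on the same aromatic carbon would bear on that question.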